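The source may report more compounds than this note shows. Statements on the series, on what has been measured and on what is new or still open speak of the compounds shown alone.

Working notes on the series. Compound 1, `CCCCCCNc1cnc(C(=O)NCc2ccccc2)cn1`, compound 2, `O=C(NCc1ccccc1)c1cncc(Cl)n1`, and compound 3, `CCCCNc1nccnc1C(=O)NCc1ccccc1`, share one core and differ in the group carried on the aromatic ring. In an ADME assay on HeLa cells (Homo sapiens) for cytotoxicity, read by microscopy, with a stated time of 6 days (a higher number here means that more compound is tolerated, a lower number that less compound is tolerated), compound 1 reaches only the limit of the method, recorded as > 100000 nM. For compound 3 the same this assay also stops at a limit, > 100000 nM. For compound 2 no value is available in this assay, the entry reading "not determined" (no result reported). Compound 2 thus stands without a number beside two neighbours whose entries are both limits, (the limit of > 100000 nM in this assay, at which 2 of the 3 values shown sit).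

The compound not yet measured is compound 4, `CCCCCNc1cncc(C(=O)NCc2ccccc2)n1`. Set against compound 2 it shows (pentylamino in place of chloro on an aromatic carbon). Among the compounds with values here, no measured pair gives the size of this kind of change in this assay, so nothing can be said about a direction beyond the scatter from compound 2 itself. Since compound 1 and compound 3 both sit at the limit of > 100000 nM in this assay, at which 2 of the 3 values shown sit, compound 4 is expected to behave in the same way. Compound 4 is therefore estimated at 100000 nM, within 40000 nM to 250000 nM, most likely again reported as a limit.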

Compound 4, minimum cytotoxic concentration: > 100000 nM
Compound 4: only a limit was reported; the forecaster's own chance of this, stated with the estimate: 85%; the middle value sits exactly at the limit.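

In this assay compound 4 gives > 100000 nM, which is a limit. Within the data shown here, compound 2 has no value to set against it, so no step between compound 2 and compound 4 can be read. The compounds shown leave open whether any change on the shared core alters the minimum cytotoxic concentration: the limit of > 100000 nM in this assay, at which 3 of the 4 values shown sit.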